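Half-life series on the shared core: a second alkoxy group

The source may hold more compounds than are shown below. What is called first, only, known or untested is meant among the compounds shown, and "the series" means these compounds.

Compound 1 `COc1ccc(C[S+]([O-])c2ncccc2C(=O)Nc2ccncc2)cc1` gives 2.14 h in an ADME assay; a lower number here means that the compound disappears faster, a higher number that the compound lasts longer.
Compound 2 `COc1cc(OC)c(C[S+]([O-])c2ncccc2C(=O)Nc2ccncc2)cc1Br` gives 0.07 h in this assay.
Compound 3 `COc1ccc(C[S+]([O-])c2ncccc2C(=O)Nc2ccncc2)c(OCCF)c1` gives < 0.02 h in this assay, which is a limit of the assay and not a number.

Compound 1 stands highest of the two numbers shown, with compound 2 an at least 100-fold lower number from compound 1 to compound 3 (2.02 log units; beyond the scatter) -sized fall not applicable; the nearest number is compound 2, far lower. Compound 4 `COc1ccc(C[S+]([O-])c2ncccc2C(=O)Nc2ccncc2)c(OC)c1` differs from compound 1 by methoxy in place of hydrogen on an aromatic carbon. Among the compounds with values here, the only measured step at that place is the one from compound 1 to compound 3, an at least 100-fold lower number from compound 1 to compound 3 (2.02 log units; beyond the scatter), which ends at the limit of < 0.02 h in this assay, at which 1 of the 3 values shown sits. A smaller alkoxy group at the same place is therefore expected to give a large fall as well, a 21-fold lower number from compound 1 to compound 4 (1.33 log units; beyond the scatter). For compound 4 the half-life is estimated at 0.1 h, between 0.02 h and 0.6 h.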

Compound 4, half-life: < 0.02 h
Compound 4: no number, only a limit; the forecaster's own chance of this, stated with the estimate: 25%; at least 5.0-fold (0.69 log units) between middle value and limit.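

Even methoxy, on the aromatic carbon ortho to a large group, gives an at least 100-fold lower number from compound 1 to compound 4 (2.02 log units; beyond the scatter), so the fall does not need the longer 2-fluoroethoxy chain. Hydrogen in place of bromo gives an at least 3.5-fold lower number from compound 2 to compound 4 (0.54 log units; beyond the scatter), so bromo goes with the longer half-life in this pair. Compound 4 gives < 0.02 h, a limit of the assay and not a number, so its step from compound 3, also a limit, cannot be read.

As far as these compounds go, how far compound 3 and compound 4 lie beyond the limit stays open. Also open, from the compounds shown here alone, is whether a smaller group at this place, such as fluoro, or an amine would retain the half-life of compound 1.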